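Cyclopropyl for isopropyl on the aryl ether oxygen

This account rests on a few compounds, and the source may have more. Where it says the series, first, only, none or still open, it means among the compounds named here.

Measured compounds:
compound 1 `Cn1cc(-c2cc(C(C)(C)O)ccc2OC2CC2)c2cc(C(=O)NCCCCCCC(=O)NO)[nH]c2c1=O` 5.5 nM
compound 2 `CC(C)Oc1ccc(C(C)(C)O)cc1-c1cn(C)c(=O)c2[nH]c(C(=O)NCc3ccc(C(=O)NO)cc3)cc12` 52 nM
compound 3 `Cn1cc(-c2ccccc2Oc2ccccc2)c2cc(C(=O)NCCCCC(=O)Nc3ccccc3N)[nH]c2c1=O` > 500 nM

In an assay on isolated protein for inhibition of protein deacetylase HDAC6 (Homo sapiens), read by fluorescence (on this read-out higher numbers stand for weaker inhibition and lower numbers for stronger inhibition), compound 2 gives 52 nM, the higher of the two numbers recorded. Compound 1 gives 5.5 nM, a lower number than compound 2 by a gap beyond the usual scatter. Compound 3 reaches only a limit of the assay, > 500 nM. Compound 4 `Cn1cc(-c2cc(C(C)(C)O)ccc2OC2CC2)c2cc(C(=O)NCc3ccc(C(=O)NO)cc3)[nH]c2c1=O` has not been measured. It differs from compound 2 in one place: cyclopropyl in place of isopropyl on an oxygen on an aromatic ring. For the measured compounds named here, no measured pair in this set isolates this change, so the step from compound 2 to compound 4 is expected to stay within the scatter, in either direction. For compound 4 the estimate in this assay is 40 nM, between 15 nM and 130 nM, a step of a 1.3-fold lower number from compound 2 to compound 4 (0.11 log units; within the scatter).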

Compound 4, half-maximal inhibitory concentration: 7.9 nM
Compound 4: middle estimate off by 5.1-fold (0.70 log units), on the high side, outside the stated range (below it).
By their numbers in this assay, from the lowest: compounds 1 and 4 (each within the scatter of the next); then compound 2. At a limit, above all of these: compound 3.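

In this assay, for the compounds shown here, cyclopropyl in place of isopropyl on an oxygen on an aromatic ring gives a 6.6-fold lower number from compound 2 to compound 4 (0.82 log units; beyond the scatter), the first reading of this change at this position. With cyclopropyl held, 4-(hydroxycarbamoyl)phenyl in place of 5-(hydroxycarbamoyl)pentyl gives a 1.4-fold higher number from compound 1 to compound 4 (0.16 log units; within the scatter), so these two groups are not told apart here. Nothing in the data shown accounts for the step at the oxygen.

Going by these compounds, whether that step carries over to the 5-(hydroxycarbamoyl)pentyl series of compound 1 stays open. On these data alone, how methyl or cyclobutyl on this oxygen would read also stays open.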